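The source may report more compounds than this note shows. Statements on the series, on what has been measured and on what is new or still open speak of the compounds shown alone.

Among the measured compounds shown here, compound 1 `CCCC(CC(=O)N1CCC(Cn2c(C)nc3cnccc32)CC1)c1ccccc1` is one of two compounds measured in a functional assay on the whole organism (arterial blood) with Rattus norvegicus as the target; a higher number here means that more compound is needed for the effect, a lower number that less compound is needed. In this assay compound 1 gives 0.0079 mg/kg, the lowest of the two numbers, and compound 2 `Cc1nc2cnccc2n1CC1CCN(C(=O)CC(c2ccccc2)c2ccccc2)CC1` gives 0.0086 mg/kg. The step of a 1.1-fold higher number from compound 1 to compound 2 (0.04 log units; within the scatter) shows that exchanging one group on the chain carbon for another stayed within the scatter. Compound 3 `COc1ccccc1N(C)CC(=O)N1CCC(Cn2c(C)nc3cnccc32)CC1` has not yet been measured in this assay. It differs from compound 1 in one place: (2-methoxyphenyl)(methyl)amino in place of 1-phenylbutyl on a saturated chain carbon bound to a carbonyl carbon. For the measured compounds named here, only the step from compound 1 to compound 2 bears on this change, and it was small; but that step kept a carbon-bound group on the chain carbon, whereas here the whole 1-phenylbutyl leaves and a nitrogen-linked group enters. A larger shift is therefore possible, most likely toward a higher number. For compound 3 the expected step is a 3.8-fold higher number from compound 1 to compound 3 (0.58 log units; beyond the scatter). The estimate for compound 3 is 0.03 mg/kg, with a range from 0.006 mg/kg to 0.15 mg/kg.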

Compound 3, dose for 50% inhibition: 0.063 mg/kg
For compound 3 the middle estimate is 2.1-fold (0.32 log units) below the measured one; the measured number falls inside the stated range.
By their numbers in this assay, from the lowest: compounds 1 and 2 (each within the scatter of the next); then compound 3.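

Both groups count the same heavy atoms and hold one six-membered aromatic ring of carbon only, yet in this assay this exchange gives an 8.0-fold higher number from compound 1 to compound 3 (0.90 log units; beyond the scatter). So at the saturated chain carbon bound to a carbonyl carbon, matching size and ring count does not keep the number in place; what differs is that the entering group has nitrogen and oxygen in place of carbon and brings hydrogen-bond acceptors. No measurement here gives a reason for the step.

The entering group changes several features at once, so the linking nitrogen, its methyl, the methoxy and the loss of the propyl chain cannot be told apart. A simple phenylamino group, or a 2-methoxybenzyl group with carbon in place of that nitrogen, would each separate part of this.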